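This account rests on a few compounds, and the source may have more. Where it says the series, first, only, none or still open, it means among the compounds named here.

In an ADME assay on MDBK cells (Bos taurus) for cytotoxicity, read by MTT assay, with a stated time of 96 h (on this read-out lower numbers stand for higher toxicity in this test and higher numbers for lower toxicity in this test), compound 1 (`COc1ccc(-c2nc3cc(/C(C)=N/NC(N)=O)ccc3[nH]2)c(OC)c1`) gives > 100000 nM which is a limit of the assay and not a number. Compound 2 (`C/C(=N\NC(N)=O)c1ccc2c(c1)nc(-c1ccccc1)n2C1CCCCC1`) gives > 100000 nM which is again a limit. Compound 3 (`C/C(=N\NC(N)=O)c1ccc2c(c1)nc(-c1ccc(C(F)(F)F)cc1)n2C1CCCCC1`) stands at > 100000 nM which is likewise only a limit. For the measured compounds named here, the one measured step is a step that the two limits leave unreadable from compound 2 to compound 3 and the whole record is the limit of > 100000 nM in this assay, at which 3 of the 3 values shown sit, so no size can be read from it. Compound 4 (`COc1ccc(-c2nc3cc(/C(C)=N/NC(N)=O)ccc3n2C2CCCCC2)c(OC)c1`) carries 2,4-dimethoxyphenyl in place of 4-(trifluoromethyl)phenyl on an aromatic carbon. Compound 1 bears that same group and its limit is > 100000 nM so no move beyond the scatter is expected in this assay here. The expected change (a number no higher from compound 3 to compound 4 (the limit leaves the size open)) is therefore none beyond the scatter. Compound 4 is estimated at 100000 nM (range 40000 nM to 200000 nM).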

Compound 4, half-maximal cytotoxic concentration: 36000 nM
Estimate against measurement, compound 4: 2.8-fold (0.44 log units) above; the measured number lies below the stated range.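

In this assay, 2,4-dimethoxyphenyl on this aromatic carbon brings the first readable number when it replaces 4-(trifluoromethyl)phenyl, giving an at least 2.7-fold lower number from compound 3 to compound 4 (0.44 log units; beyond the scatter), or phenyl, giving an at least 2.7-fold lower number from compound 2 to compound 4 (0.44 log units; beyond the scatter). Cyclohexyl in place of hydrogen on the aromatic nitrogen gives an at least 2.7-fold lower number from compound 1 to compound 4 (0.44 log units; beyond the scatter), so among these compounds neither group alone leaves the limit, and only the two together give a number. The true size of all three steps stays open: the limit of > 100000 nM in this assay, at which 3 of the 4 values shown sit.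

The compounds shown leave open whether a single methoxy or an amine on the phenyl ring would also give a readable number. On these data alone, whether ethyl in place of cyclohexyl would do the same also stays open.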